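A few compounds are considered here, and "the series" means these few. Any claim that something is new, unique, unknown or untested is made for them only; others in the source may bear on it.

Of the compounds shown here, three built on one shared core have been tested in a functional assay on HL-60 cells (Homo sapiens) for inhibition, read by MTT assay, with a stated time of 48 h; a lower number here means a stronger inhibitor of growth, a higher number a weaker inhibitor of growth. Compound 1 `CN1CC[C@H](c2c(O)cc(O)c3c(=O)cc(/C=C/c4ccccc4)oc23)[C@H](O)C1`, with no substituent on its aromatic ring, gives 1000 nM. Compound 2 `CN1CC[C@H](c2c(O)cc(O)c3c(=O)cc(/C=C/c4cccc(Cl)c4)oc23)[C@H](O)C1`, with a chloro on that ring, gives 20000 nM. Compound 3 `CN1CC[C@H](c2c(O)cc(O)c3c(=O)cc(/C=C/c4cccc(F)c4)oc23)[C@H](O)C1`, which carries a 3-fluorophenyl, gives 8000 nM. Compound 3 therefore holds the middle of the three numbers, a weaker growth inhibitor than compound 1 and a stronger one than compound 2.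

Compound 4 `CN1CC[C@H](c2c(O)cc(O)c3c(=O)cc(/C=C/c4ccccc4F)oc23)[C@H](O)C1` has the same atoms as compound 3, joined differently: 2-fluorophenyl in place of 3-fluorophenyl on a double-bonded chain carbon bound to a double-bonded chain carbon. Among the measured compounds shown here, no tested pair shows a fluoro moving around the ring, so no measurement captures this change directly. The closest evidence is indirect. Putting fluoro on the ring gave an 8.0-fold higher number from compound 1 to compound 3 (0.90 log units; beyond the scatter), chloro gave a 20-fold higher number from compound 1 to compound 2 (1.30 log units; beyond the scatter), and exchanging chloro for fluoro gave a 2.5-fold lower number from compound 2 to compound 3 (0.40 log units; beyond the scatter). These steps show that the number responds strongly to what the ring carries, but they do not show how it responds to where the fluoro sits. Since compound 4 still carries a fluoro, only a partial recovery towards the value of compound 1 seems reasonable. The expected change is a 1.6-fold lower number from compound 3 to compound 4 (0.20 log units; within the scatter), a small step that may not clear the scatter. For compound 4, the estimated value is 5000 nM, with an expected range from 1500 nM to 15000 nM.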

Compound 4, concentration for 50% growth inhibition: 8000 nM
The estimate for compound 4 lay 1.6-fold (0.20 log units) below the measured number; low and high end bracket the measured number.
By their numbers in this assay, from the lowest: compound 1; then compounds 3 and 4 (each within the scatter of the next); then compound 2.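

In this assay, moving the fluoro gives no change at the digits printed from compound 3 to compound 4 (within the scatter), the first direct test of where this atom sits, and the swap of 3-fluorophenyl for 2-fluorophenyl makes no detectable difference between these two compounds. Both fluoro compounds therefore stand equally far from the compound with a bare ring, with an 8.0-fold higher number from compound 1 to compound 3 (0.90 log units; beyond the scatter) and an 8.0-fold higher number from compound 1 to compound 4 (0.90 log units; beyond the scatter), so for these two placings, the presence of the fluoro matters to the number while the choice between them does not, and the new compound also keeps the distance from the chloro compound, with a 2.5-fold lower number from compound 2 to compound 4 (0.40 log units; beyond the scatter). No measurement is available here that explains why the two placings match.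

From the compounds shown here alone, the chloro appears only as 3-chlorophenyl, so it remains open whether moving that larger halogen around the ring would be as uneventful as moving the fluoro. It also remains open whether any ring substituent, such as a methoxy group or an amine, could match or improve on the bare ring, since compound 1 at 1000 nM has the lowest number of the compounds shown.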